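Working notes: pyridin-4-yl in place of furan-2-yl

The source may report more compounds than this note shows. Statements on the series, on what has been measured and on what is new or still open speak of the compounds shown alone.

In a functional assay on HeLa cells (Homo sapiens) for cytotoxicity, read by ELISA, with a stated time of 2 days (on this read-out lower numbers stand for stronger inhibition and higher numbers for weaker inhibition), compound 1 `Oc1cccc(-c2cc(-c3ccccc3)nc(-c3ccccc3)c2)c1` gives 15100 nM. In the same assay compound 2 `Oc1cccc(-c2cc(-c3ccccc3)nc(-c3ccco3)c2)c1` gives 10900 nM. Among the compounds with values here, these are the only two numbers so far, and they lie within the scatter of each other, so compound 2 stands level with compound 1 and neither can be ranked.

Compound 3 `Oc1cccc(-c2cc(-c3ccccc3)nc(-c3ccncc3)c2)c1` carries pyridin-4-yl in place of furan-2-yl on an aromatic carbon, next to the ring nitrogen of the shared core (pyridin-4-yl in place of furan-2-yl on an aromatic carbon). The phenyl and 3-hydroxyphenyl groups stay unchanged.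

Within the data shown here, one measured step bears on this change, made at the same place: a 1.4-fold lower number from compound 1 to compound 2 (0.14 log units; within the scatter). That exchange of phenyl for furan-2-yl stayed within the scatter in this assay. Among the measured compounds shown here, no measured compound yet carries pyridin-4-yl, so this single step is thin support and the range must stay wide. No clear direction can be drawn from it, and no shift beyond the scatter is expected.

For the measured compounds named here, the estimated change is a 1.0-fold higher number from compound 2 to compound 3 (0.00 log units; within the scatter), with no real step expected. For compound 3 the expected value is 11000 nM, with an estimated range from 4500 nM to 25000 nM.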

Compound 3, half-maximal inhibitory concentration: 15000 nM
Compound 3: the middle estimate sits 1.4-fold (0.13 log units) below what was measured; measured number inside the range.
By their numbers in this assay, from the lowest: compounds 2, 3 and 1 (each within the scatter of the next).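

In this assay, three groups can now be compared on this aromatic carbon next to the ring nitrogen, and none separates from the others: pyridin-4-yl in place of furan-2-yl gives a 1.4-fold higher number from compound 2 to compound 3 (0.14 log units; within the scatter), and pyridin-4-yl in place of phenyl gives a 1.0-fold lower number from compound 1 to compound 3 (0.00 log units; within the scatter). Compound 3 adds the first pyridin-4-yl to the series, so this position now reads flat across phenyl, a five-membered aromatic ring with a hetero atom and a six-membered aromatic ring with a hetero atom, whereas the earlier pair covered only the first two. No other measurement is at hand to interpret this flat reading.

The compounds shown leave open whether any group beyond these aromatic rings, such as an aminomethyl group, a carboxylic acid or a longer alkyl chain, would move the number at this position beyond the scatter. They also say nothing about the 3-hydroxyphenyl and phenyl groups, which stay unchanged here, so replacing the hydroxyl with a methoxy group or an amine remains an untested question within this set.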